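The compounds below may be only part of what the source reports. "The series", "measured", "known", "first", "only" and "open" are said of these compounds alone.

In a functional assay on MG-63 cells (Homo sapiens) for antiproliferative activity, read by MTT assay, with a stated time of 3 days (on this read-out higher numbers stand for weaker inhibition and lower numbers for stronger inhibition), compound 2 (`O=C1Nc2ccccc2/C1=[N+](\[O-])Cc1ccccc1`) gives 77000 nM, level with compound 1 (`O=C1Nc2ccc([N+](=O)[O-])cc2/C1=[N+](\[O-])Cc1ccccc1`) at 77000 nM. Compound 3 (`CN1C(=O)/C(=[N+](/[O-])Cc2ccccc2)c2ccccc21`) differs from compound 2 by methyl in place of hydrogen on an amide-type nitrogen in a ring. Going by the values given here, the only measured step, no change at the digits printed from compound 1 to compound 2 (within the scatter), swaps nitro for hydrogen on an aromatic carbon, so it leaves the amide-type nitrogen untouched and bears on this change only indirectly. No shift beyond the scatter is therefore expected in this assay, and the expected step is a 1.1-fold lower number from compound 2 to compound 3 (0.04 log units; within the scatter). For compound 3 the estimated value is 70000 nM, with an expected range from 30000 nM to 150000 nM.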

Compound 3, half-maximal inhibitory concentration: 77000 nM
Beside the measured number, compound 3's estimate is 1.1-fold (0.04 log units) below it; the range from low to high includes it.
By their numbers in this assay, from the lowest: compounds 1, 2 and 3 (each within the scatter of the next).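

In this assay, going by these compounds alone, methyl in place of hydrogen on an amide-type nitrogen in a ring gives no change at the digits printed from compound 2 to compound 3 (within the scatter) and is the first measured change at this nitrogen, since the earlier step touched only an aromatic carbon. The amide hydrogen of compound 2 can thus give way to methyl without a shift beyond the scatter. Nothing measured here offers an explanation for this result. Still open, on these data alone, is whether a longer chain or a carboxylic acid on this nitrogen would read the same. Also open, as far as these compounds go, is whether methyl here would read the same with nitro on the aromatic carbon.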